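Swapping Cyclobutylmethyl for an Ether-Bearing Chain

The source may report more compounds than this note shows. Statements on the series, on what has been measured and on what is new or still open speak of the compounds shown alone.

Compound 1 `O=C(CN(CC1CC1)C(=O)c1ccc(-c2ccccn2)cc1)Nc1cc(F)cc(F)c1`: 3.1
Compound 2 `O=C(CN(CC1CCC1)C(=O)c1ccc(-c2ccccn2)cc1)Nc1cc(F)cc(F)c1`: 3.5

In a physicochemical assay for lipophilicity (a higher number here means a more lipophilic compound, a lower number a more polar compound), compound 2 stands higher of the two, at 3.5. Compound 3 `COCC(C)N(CC(=O)Nc1cc(F)cc(F)c1)C(=O)c1ccc(-c2ccccn2)cc1` carries 1-(methoxymethyl)ethyl in place of cyclobutylmethyl on an amide-type nitrogen. Within the data shown here, one measured step touches this place, the modest a number 0.40 log units higher from compound 1 to compound 2 (beyond the scatter). Among the measured compounds shown here, it exchanged one carbon-only ring for another, so it guides the change only loosely, and no measured compound has oxygen in this group. A downward move somewhat larger than that step is expected, an estimated a number 0.70 log units lower from compound 2 to compound 3 (beyond the scatter). Compound 3 is expected at 2.8, with a range from 2.4 to 3.2.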

Compound 3, distribution coefficient: 3
Estimate against measurement, compound 3: 0.20 log units below, within the range that was stated.
By their numbers in this assay, from the lowest: compounds 3 and 1 (each within the scatter of the next); then compound 2.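

Among these compounds, exchanging cyclobutylmethyl for 1-(methoxymethyl)ethyl on the amide-type nitrogen gives a clear shift in this assay (a number 0.50 log units lower from compound 2 to compound 3 (beyond the scatter)), the first reading for a group with oxygen at this position. Set against cyclopropylmethyl, the same group gives no separable difference (a number 0.10 log units lower from compound 1 to compound 3 (within the scatter)), so at this position an open ether-bearing chain and the smaller carbon ring read alike. Nothing available explains these readings.

The compounds shown do not separate the oxygen of 1-(methoxymethyl)ethyl from the absence of a ring. They also leave open how an amine or a carboxylic acid would read on this nitrogen.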